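This account rests on a few compounds, and the source may have more. Where it says the series, first, only, none or still open, it means among the compounds named here.

Measured compounds:
compound 1 `Cc1nc(-c2ccc(Cl)cc2)sc1C(=O)CSc1nc(-c2ccc(Cl)c(Cl)c2)c(C#N)c(=O)[nH]1` — 97.1%
compound 2 `Cc1nc(-c2ccccc2)sc1C(=O)CSc1nc(-c2ccc(Cl)c(Cl)c2)c(C#N)c(=O)[nH]1` — 92.5%
compound 3 `COc1ccc(-c2nc(C)c(C(=O)CSc3nc(-c4ccc(Cl)c(Cl)c4)c(C#N)c(=O)[nH]3)s2)cc1` — 88.6%

All three numbers come from a functional assay on U-87MG ATCC cells for antiproliferative activity against U-87 MG (Homo sapiens), read by MTT assay, with a stated time of 48 h, tested at 10 uM; on this read-out lower numbers stand for a stronger effect and higher numbers for a weaker effect at the one concentration tested. Compound 1 holds the top number of the three; the step of a number 4.6 percentage points lower from compound 1 to compound 2 (within the scatter) and the step of a number 8.5 percentage points lower from compound 1 to compound 3 (within the scatter) are small, and a number 3.9 percentage points lower from compound 2 to compound 3 (within the scatter) is likewise small. Compound 4 `COc1cccc(-c2nc(SCC(=O)c3sc(-c4ccc(Cl)cc4)nc3C)[nH]c(=O)c2C#N)c1` has not been measured. Its change from compound 1 is 3-methoxyphenyl in place of 3,4-dichlorophenyl on an aromatic carbon. Among the measured compounds shown here, no measured step touches this part of the shared core: the three steps recorded each exchange a single group on an aromatic carbon elsewhere in the structure, and each stayed within the scatter. On that basis no step beyond the scatter is expected in this assay, with a slight lean downward. Compound 4 is therefore estimated at 90%, range 76% to 100%, an expected step of a number 7.1 percentage points lower from compound 1 to compound 4 (within the scatter).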

Compound 4, a percentage reported as activity, at one concentration (the size of the read-out at that concentration, not a potency): 89.7%
Beside the measured number, compound 4's estimate is 0.3 percentage points above it; the measured number falls inside the stated range.
By their numbers in this assay, from the lowest: compounds 3, 4, 2 and 1 (each within the scatter of the next).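

In this assay, exchange at the aromatic carbon ortho to a cyano group gives a number 7.4 percentage points lower from compound 1 to compound 4 (within the scatter) and so stays within the scatter. The earlier steps shown here showed this only for single groups elsewhere in the structure; here a whole aryl group changes, 3-methoxyphenyl in place of 3,4-dichlorophenyl, also without a step beyond the scatter. Nothing available explains this outcome.

Open, on these data alone, is whether a non-aryl group at this carbon, such as an amine or a carboxylic acid, would give a step beyond the scatter.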